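Ester Exchange on a Thiophene Analogue: Expected Binding

This account rests on a few compounds, and the source may have more. Where it says the series, first, only, none or still open, it means among the compounds named here.

Measured compounds and their values in the receptor binding read-out:
compound 1, `CC1=C(C(=O)OC(C)(C)C)C(c2ccoc2)NC(=O)N1C`: 12%
compound 2, `CC1=C(C(=O)OCc2ccccc2)C(c2ccoc2)NC(=O)N1C`: 25%
compound 3, `CC1=C(C(=O)OC(C)(C)C)C(c2cccs2)NC(=O)N1C`: 22%

The three compounds share one core and were all tested in an assay on membranes from HeLa cells for displacement of a labelled ligand from adenosine receptor A3 (Homo sapiens), read by scintillation counting, with a stated time of 180 min, tested at 1 uM; on this read-out higher numbers stand for more inhibition at the one concentration tested (going by the name of the read-out) and lower numbers for less inhibition. Compound 1 gives 12%. Compound 2 differs from it by benzyl in place of tert-butyl on an oxygen next to a carbonyl group, and this change gives a number 13 percentage points higher from compound 1 to compound 2 (beyond the scatter). Compound 3 differs from compound 1 by thiophen-2-yl in place of furan-3-yl on a saturated ring carbon, a change that gives a number 10 percentage points higher from compound 1 to compound 3 (within the scatter); in this read-out compound 3 gives 22%.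

Compound 4, `CC1=C(C(=O)OCc2ccccc2)C(c2cccs2)NC(=O)N1C`, has not been measured. It differs from compound 3 by benzyl in place of tert-butyl on an oxygen next to a carbonyl group. Going by the values given here, this is the same change as the one between compound 1 and compound 2: the group that leaves, the group that enters and the place on the core are described in the same words for both pairs. The two cores differ only in the way described for compound 1 and compound 3, in the group on the saturated ring carbon.

Among the compounds with values here, since the only measured example of this change, from compound 1 to compound 2, gave a modest rise, a step of about the same size is expected from compound 3 to compound 4, namely a number 12 percentage points higher from compound 3 to compound 4 (beyond the scatter). That expectation rests on a single pair, so the range around it is kept wide. In this assay compound 4 is estimated at 34%, with a likely span from 20% to 50%.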

Compound 4, a percentage reported as inhibition, at one concentration (the size of the read-out at that concentration, not a potency): 18%
Beside the measured number, compound 4's estimate is 16 percentage points above it; measured number outside the range, below it.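

In this assay, benzyl in place of tert-butyl on an oxygen next to a carbonyl group did not repeat its earlier rise on the core carrying thiophen-2-yl, giving a number 4 percentage points lower from compound 3 to compound 4 (within the scatter), and the two steps differ: the same change on two cores in this assay, a number 13 percentage points higher (beyond the scatter) from compound 1 to compound 2 and a number 4 percentage points lower (within the scatter) from compound 3 to compound 4, 17 percentage points apart, beyond the scatter of two such steps. Seen from the other side, thiophen-2-yl in place of furan-3-yl on a saturated ring carbon gave a number 7 percentage points lower from compound 2 to compound 4 (within the scatter), and this change also differs between its two cores: the same change on two cores in this assay, a number 10 percentage points higher (within the scatter) from compound 1 to compound 3 and a number 7 percentage points lower (within the scatter) from compound 2 to compound 4, 17 percentage points apart, beyond the scatter of two such steps. Within these compounds, then, neither change can be carried from one core to the other as a fixed step, but the finding rests on a single set of compounds read at one concentration, and it shows neither why the steps differ nor how either change would behave on any other core.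

The compounds shown leave open whether an ethyl group, a longer chain or a cyclohexylmethyl group on that oxygen would follow the tert-butyl or the benzyl pattern. They also leave open how the same exchange would read with phenyl, furan-2-yl or thiophen-3-yl on the saturated ring carbon.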